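An Ethyl for a Methyl at the Assay Limit

The source may report more compounds than this note shows. Statements on the series, on what has been measured and on what is new or still open speak of the compounds shown alone.

Compound 1 `CN1C/C(=C\c2ccc(F)c(F)c2)C(=O)/C(=C/c2ccc(F)c(F)c2)C1` gives 470 nM
Compound 2 `CN1C/C(=C\c2c(F)cc(F)cc2F)C(=O)/C(=C/c2c(F)cc(F)cc2F)C1` gives > 10000 nM
Compound 3 `CCN1C/C(=C\c2cc(F)c(F)cc2F)C(=O)/C(=C/c2cc(F)c(F)cc2F)C1` gives 520 nM

Among the compounds with values here, all three results come from a functional assay on DLD-1 cells (Homo sapiens) for cytotoxicity, read by MTT assay, with a stated time of 72 h (on this read-out higher numbers stand for weaker inhibition and lower numbers for stronger inhibition), and no two of the compounds differ in one place only. Compound 1 at 470 nM and compound 3 at 520 nM lie within the usual scatter of each other. For compound 2 the result is a limit and not a number: > 10000 nM is all that is known. Compound 2 thus stands at the limit of > 10000 nM in this assay, at which 1 of the 3 values shown sits, without a measured value of its own.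

Compound 4 `CCN1C/C(=C\c2c(F)cc(F)cc2F)C(=O)/C(=C/c2c(F)cc(F)cc2F)C1` differs from compound 2 in one place, methyl in place of hydrogen on a saturated chain carbon bound to an amine nitrogen in a ring and read one bond further out this is methyl to ethyl. Within the data shown here, no measured pair shows this change alone. Compound 1 carries the methyl and compound 3 the ethyl, but they differ elsewhere too, so their values offer only weak guidance. In this assay no step beyond the scatter is expected for a number no higher from compound 2 to compound 4 (the limit leaves the size open) and no direction can be favoured, so a second result at the limit is quite possible. Compound 4 is estimated at 10000 nM with an expected range from 3000 nM to 30000 nM in this estimate.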

Compound 4, half-maximal inhibitory concentration: 1400 nM
Compound 4: the middle estimate sits 7.1-fold (0.85 log units) above what was measured, outside the stated range (below it).
By their numbers in this assay, from the lowest: compounds 1 and 3 (each within the scatter of the next); then compound 4. At a limit, above all of these: compound 2.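

This pair is the first among the compounds shown to isolate one change, and in this assay methyl in place of hydrogen on a saturated chain carbon bound to an amine nitrogen in a ring, read one bond further out as methyl to ethyl, brings an at least 7.1-fold lower number from compound 2 to compound 4 (0.85 log units; beyond the scatter). Within the data shown here, compound 1 and compound 3 also carry methyl and ethyl, but they differ elsewhere as well, so only this pair ties the step to the change alone, with compound 4 reading 1400 nM on the shared core of compound 2. Compound 2 has a limit and not a number, so the full size of the step stays unknown: the limit of > 10000 nM in this assay, at which 1 of the 4 values shown sits.

The compounds shown leave open whether the same change would give a step of this kind with the other fluorine patterns seen in compound 1 and compound 3. They also leave open how a longer chain, such as propyl, or a benzyl group in this place would read in this assay.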